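Nitro to Bromo: An Untested Step in Growth Inhibition

A few compounds are considered here, and "the series" means these few. Any claim that something is new, unique, unknown or untested is made for them only; others in the source may bear on it.

Compound 2 `COc1cc(C2CC(c3ccc([N+](=O)[O-])cc3)=NN2C(C)=O)ccc1OCc1cn(Cc2ccc([N+](=O)[O-])cc2)nn1` gives 72% in a functional assay on A549 cells (Homo sapiens) for inhibition, read by sulforhodamine B assay, tested at 100 uM (a lower number here means less inhibition of growth, a higher number more inhibition of growth at the concentration tested), the higher of the two numbers at hand. Compound 1 `COc1cc(C2CC(c3ccc(OCc4cn(Cc5ccc([N+](=O)[O-])cc5)nn4)cc3)=NN2C(C)=O)ccc1Oc1cn(Cc2ccc([N+](=O)[O-])cc2)nn1` gives 42% in this assay, a gap from compound 2 that lies beyond the scatter. Compound 3 `COc1cc(C2CC(c3ccc(Br)cc3)=NN2C(C)=O)ccc1OCc1cn(Cc2ccc([N+](=O)[O-])cc2)nn1` differs from compound 2 by bromo in place of nitro on an aromatic carbon. Going by the values given here, no measured pair shows this change, so its effect is unknown from these data. Compound 3 is expected to keep much of the inhibition, with an estimated step of a number 12 percentage points lower from compound 2 to compound 3 (beyond the scatter) that may stay within the scatter or show a modest loss. The estimate for compound 3 is 60%, ranging from 35% to 80%.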

Compound 3, percent growth inhibition at one concentration: 17%
Compound 3: middle estimate off by 43 percentage points, on the high side; the whole stated range lies above it.
By their numbers in this assay, from the lowest: compound 3; then compound 1; then compound 2.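

Replacing 4-nitrophenyl with 4-bromophenyl gives a number 55 percentage points lower from compound 2 to compound 3 (beyond the scatter) in this assay, so growth inhibition at the concentration tested depends strongly on what this aromatic carbon carries. The earlier compounds shown here offered no pair differing at this place alone, and this step shows that bromo does not stand in for nitro here. Nothing at hand accounts for the size of the step. On these data alone, whether an amine, a nitrile or a carboxylic acid at this position would keep the inhibition seen with compound 2 remains open.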